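From 4-aminophenyl to 3-methylphenyl at the assay limit

The source may hold more compounds than are shown below. What is called first, only, known or untested is meant among the compounds shown, and "the series" means these compounds.

Measured so far in a functional assay on COLO 205 cells (Homo sapiens) for cytotoxicity, read by MTT assay, with a stated time of 48 h (on this read-out higher numbers stand for weaker inhibition and lower numbers for stronger inhibition), and each value a limit rather than a number:
- Compound 1 `COc1ccccc1Nc1nc(-c2cccc(F)c2)nc2ccc(F)cc12` gives > 50000 nM as a limit
- Compound 2 `Fc1cccc(-c2nc(Nc3cccc(Cl)c3)c3cc(F)ccc3n2)c1` gives > 50000 nM as a limit
- Compound 3 `Nc1ccc(Nc2nc(-c3cccc(F)c3)nc3ccc(F)cc23)cc1` gives > 50000 nM as a limit

Compound 3 therefore stands at > 50000 nM as a limit of this assay and not as a measured number. It shares this position with the other two compounds, for the whole set rests on the limit of > 50000 nM in this assay, at which 3 of the 3 values shown sit, and on nothing more precise.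

Compound 4 (`Cc1cccc(Nc2nc(-c3cccc(F)c3)nc3ccc(F)cc23)c1`) carries 3-methylphenyl in place of 4-aminophenyl on a nitrogen on an aromatic ring. Within the data shown here, three measured steps bear on this change, since each swaps the group at that same place. They are a step that the two limits leave unreadable from compound 1 to compound 2 and then a step that the two limits leave unreadable from compound 1 to compound 3 and finally a step that the two limits leave unreadable from compound 2 to compound 3 with no size to carry over from any of them. Neither 2-methoxyphenyl, 3-chlorophenyl nor 4-aminophenyl brought a number into view, so no direction can be argued. In this assay the expected outcome is a step that the limit leaves unreadable from compound 3 to compound 4 and no readable change is anticipated. Compound 4 is estimated at 60000 nM within an expected range of 20000 nM to 100000 nM and a limit rather than a number is expected for it too.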

Compound 4, half-maximal inhibitory concentration: > 50000 nM
Compound 4: only a limit was reported; the forecaster's own chance of this, stated with the estimate: 75%; the middle value is on the limit's open side.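

In this assay compound 4 gives > 50000 nM as a limit and not as a number. No step between compound 4 and compound 1, compound 2 or compound 3 can be read, and the whole set rests on one limit: the limit of > 50000 nM in this assay, at which 4 of the 4 values shown sit.

The compounds shown leave open whether any group at this place on the nitrogen gives a measurable value in this assay at all.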